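Hydrazone aryl exchange on a shared urea core

This account rests on a few compounds, and the source may have more. Where it says the series, first, only, none or still open, it means among the compounds named here.

Compound 1, `CN(C)CCn1cnnc1-c1cc(Oc2ccc(NC(=O)N/N=C/c3c[nH]c4ccccc34)cc2F)ccn1`, in a functional assay on MKN-45 cells (Homo sapiens) for cytotoxicity, read by MTT assay, with a stated time of 72 h (on this read-out higher numbers stand for weaker inhibition and lower numbers for stronger inhibition), gives 790 nM.
Compound 2, `COc1ccc(/C=N/NC(=O)Nc2ccc(Oc3ccnc(-c4nncn4CCN(C)C)c3)c(F)c2)c(OC)c1OC`, in this assay gives 2020 nM.
Compound 3, `CN(C)CCn1cnnc1-c1cc(Oc2ccc(NC(=O)N/N=C/c3ccc(O)c(F)c3)cc2F)ccn1`, in this assay gives 1970 nM.

Compound 3 stands second highest of the three numbers. Its value and that of compound 2 lie within the scatter of each other, as the step of a 1.0-fold lower number from compound 2 to compound 3 (0.01 log units; within the scatter) shows, while compound 1 sits apart from both through the steps of a 2.6-fold higher number from compound 1 to compound 2 (0.41 log units; beyond the scatter) and a 2.5-fold higher number from compound 1 to compound 3 (0.40 log units; beyond the scatter). Compound 4, `COc1ccc(/C=N/NC(=O)Nc2ccc(Oc3ccnc(-c4nncn4CCN(C)C)c3)c(F)c2)cc1O`, differs from compound 3 in one place: 3-hydroxy-4-methoxyphenyl in place of 3-fluoro-4-hydroxyphenyl on a carbon with a double bond to nitrogen. Among the compounds with values here, no measured step covers this exact exchange. What bears on it is that two different substituted phenyl groups at this position, in compound 2 and compound 3, gave numbers within the scatter of each other, and only the indolyl group of compound 1 set itself apart. Compound 4 is therefore expected to show a step of a 1.0-fold higher number from compound 3 to compound 4 (0.01 log units; within the scatter), nothing beyond the scatter. Compound 4 is estimated at 2000 nM in this assay, with a range from 1000 nM to 4500 nM.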

Compound 4, half-maximal inhibitory concentration: 2510 nM
Beside the measured number, compound 4's estimate is 1.3-fold (0.10 log units) below it; low and high end bracket the measured number.
By their numbers in this assay, from the lowest: compound 1; then compounds 3, 2 and 4 (each within the scatter of the next).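

In this assay, a third substituted phenyl group on the carbon with a double bond to nitrogen, 3-hydroxy-4-methoxyphenyl, falls within the scatter of the other two, with a 1.3-fold higher number from compound 3 to compound 4 (0.11 log units; within the scatter) and a 1.2-fold higher number from compound 2 to compound 4 (0.09 log units; within the scatter) so that compounds 2, 3 and 4 form one cluster despite their different phenyl substituents. Compound 1 also stands apart from this newest member, with a 3.2-fold higher number from compound 1 to compound 4 (0.50 log units; beyond the scatter) as the largest step shown, which leaves 1H-indol-3-yl as the only group here that separates from the rest. Nothing available explains this separation.

As far as these compounds go, it remains open whether the separation belongs to the indolyl group alone, which a naphthyl or 1-methylindol-3-yl group at this place could test. Also open, from the compounds shown here alone, is whether a phenyl group carrying an amine or a carboxylic acid would stay within the cluster.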